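This account rests on a few compounds, and the source may have more. Where it says the series, first, only, none or still open, it means among the compounds named here.

In a functional assay on HCC827 cells (Homo sapiens) for antiproliferative activity, read by MTT assay, with a stated time of 72 h (on this read-out higher numbers stand for weaker inhibition and lower numbers for stronger inhibition), compound 2 `CN1CCN(c2ccc(Nc3ncc4nc(Sc5ccccc5)n(C5CCCC5)c4n3)cc2)CC1` gives 51.2 nM and compound 3 `CN1CCN(c2ccc(Nc3ncc4nc(SCc5cccnc5)n(C5CCCC5)c4n3)cc2)CC1` gives 517 nM. Compound 3 therefore holds the higher of the two actual numbers, and a 10-fold higher number from compound 2 to compound 3 (1.00 log units; beyond the scatter) lies beyond the scatter. That step places (pyridin-3-yl)methyl in place of phenyl on a sulfur. Compound 1 `CN1CCN(c2ccc(Nc3ncc4nc([S+]([O-])Cc5cccnc5)n(C5CCOCC5)c4n3)cc2)CC1` is reported only as a limit of the assay, > 10000 nM.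

Compound 4 `CN1CCN(c2ccc(Nc3ncc4nc([S+]([O-])Cc5cccnc5)n(C5CCCC5)c4n3)cc2)CC1` alters compound 3 at a single place: a group of 9 heavy atoms (6 carbon, 1 nitrogen, 1 oxygen, 1 sulfur; one six-membered aromatic ring with 1 hetero atom) in place of a group of 8 heavy atoms (6 carbon, 1 nitrogen, 1 sulfur; one six-membered aromatic ring with 1 hetero atom), on an aromatic carbon. The group that leaves is ((pyridin-3-yl)methyl)sulfanyl. Within the data shown here, no measured step covers this exact change, so the evidence is indirect. The step to compound 3, a 10-fold higher number from compound 2 to compound 3 (1.00 log units; beyond the scatter), shows that a change on this sulfur can move the number well beyond the scatter. The group that enters is also found in compound 1, which points towards a higher number in this assay. The expected change is a 4.8-fold higher number from compound 3 to compound 4 (0.68 log units; beyond the scatter). The estimate for compound 4 is 2500 nM, within an expected range of 700 nM to 9000 nM.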

Compound 4, half-maximal inhibitory concentration: 2350 nM
Estimate against measurement, compound 4: 1.1-fold (0.03 log units) above; measured number inside the range.
By their numbers in this assay, from the lowest: compound 2; then compound 3; then compound 4. At a limit, above all of these: compound 1.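

In this assay, the sulfur on this aromatic carbon matters in its own right, not only through the group it carries: with the (pyridin-3-yl)methyl group kept, adding one oxygen to the sulfur gives a 4.5-fold higher number from compound 3 to compound 4 (0.66 log units; beyond the scatter). Measured against the phenyl on sulfur, the replacement of the whole group gives a 46-fold higher number from compound 2 to compound 4 (1.66 log units; beyond the scatter), the largest step among these compounds. The ring on the aromatic nitrogen also counts, as cyclopentyl in place of oxan-4-yl gives an at least 4.2-fold lower number from compound 1 to compound 4 (0.62 log units; beyond the scatter), and this step is only a minimum, as the number for compound 1 is a limit of the assay: the limit of > 10000 nM in this assay, at which 1 of the 4 values shown sits.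

Going by these compounds, whether the added oxygen would cost as much on the phenyl-bearing sulfur of compound 2 remains open. Also open, on these data alone, is what an amine nitrogen in place of the sulfur would give at this position.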